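A few compounds are considered here, and "the series" means these few. Any claim that something is new, unique, unknown or untested is made for them only; others in the source may bear on it.

Measured in a functional assay on PANC-1 cells (Homo sapiens) for antiproliferative activity, read by sulforhodamine B assay, with a stated time of 48 h; a lower number here means a stronger inhibitor of growth, a higher number a weaker inhibitor of growth:
- compound 1 `Cc1ccc(-c2nnc(C3=C(Cl)c4cc(C)c(C)cc4CCC3)o2)cc1`: 3880 nM
- compound 2 `COc1ccc([N+](=O)[O-])c(-c2nnc(C3=C(Cl)c4cc(C)c(C)cc4CCC3)o2)c1OC`: 957 nM

Of these two, compound 1 stands higher at 3880 nM, which makes it the weaker inhibitor of growth of the pair. Compound 2 gives the lower number, 957 nM, and the gap between them lies beyond the scatter.

The next compound, compound 3 `Cc1cc2c(cc1C)C(Cl)=C(c1nnc(-c3cccc(I)c3)o1)CCC2`, has not yet been measured in this assay. It keeps the shared core of compound 1 and carries 3-iodophenyl in place of 4-methylphenyl on an aromatic carbon. Within the data shown here, neither measured compound carries 3-iodophenyl, so the data offer no direct precedent for this change. The starting point for the expectation is therefore compound 1 at 3880 nM, and the same core in compound 2 reaches 957 nM with another group in that place. A small move toward a lower number is expected, but nothing beyond the scatter. The expected change is a 1.6-fold lower number from compound 1 to compound 3 (0.19 log units; within the scatter). For compound 3 the estimated value is 2500 nM, with an expected range from 900 nM to 7000 nM.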

Compound 3, concentration for 50% growth inhibition: 4120 nM
Compound 3: the middle estimate sits 1.6-fold (0.22 log units) below what was measured, and the stated range covers the measured number.
By their numbers in this assay, from the lowest: compound 2; then compounds 1 and 3 (each within the scatter of the next).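

In this assay, putting 3-iodophenyl in place of 4-methylphenyl on the aromatic carbon of the five-membered aromatic ring gives a 1.1-fold higher number from compound 1 to compound 3 (0.03 log units; within the scatter), so the two compounds cannot be told apart. Among these compounds, this is the first reading at this position with a halogen on the phenyl ring, and it shows that a single iodine in place of the methyl group, with the core of compound 1 kept, does not on its own bring the number to the level of compound 2 at 957 nM. No independent measurement is available to explain why these two groups read alike.

The step replaces the substituent and alters its numbered place on the phenyl ring in one move, so 4-iodophenyl and 3-methylphenyl would be needed to read those two changes separately. As far as these compounds go, it also remains open whether the lower number of compound 2 at 957 nM goes with its nitro group, its two methoxy groups or their combination, and whether an amine or a carboxylic acid on the phenyl ring would move the number at all.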